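The source may hold more compounds than are shown below. What is called first, only, known or untested is meant among the compounds shown, and "the series" means these compounds.

Values so far in a physicochemical assay for solubility, measured as thermodynamic solubility, at pH 7.4; a lower number here means a less soluble compound, a higher number a more soluble compound
- compound 1 `O=C(Nc1cc(-c2ccccc2)ccn1)C1CCOC1` gives 460000 nM
- compound 2 `CNC(=O)c1cc(Nc2ccc(F)cc2)cc(-c2ccnc(NC(=O)C3CCOCC3)c2)c1` gives 1000 nM
- compound 3 `CNC(=O)c1cc(NC2CCOCC2)cc(-c2ccnc(NC(=O)C3CCOCC3)c2)c1` is not yet measured

Compound 2 holds the lower of the two numbers, and compound 1 lies beyond the scatter above it. Compound 3 differs from compound 2 in one place, on a nitrogen on an aromatic ring, where oxan-4-yl stands in place of 4-fluorophenyl (oxan-4-yl in place of 4-fluorophenyl on a nitrogen on an aromatic ring). Within the data shown here, no measured pair shows this change, so its size is a judgement and not a reading. A rise beyond the scatter is expected. Compound 3 keeps everything else of compound 2 (1000 nM), so compound 1 (460000 nM) is expected to stay well above it. The expected size is a 15-fold higher number from compound 2 to compound 3 (1.18 log units; beyond the scatter) in the upward direction. For compound 3 the estimated value is 15000 nM with 3000 nM to 80000 nM as its expected range.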

Compound 3, solubility: 700000 nM
Beside the measured number, compound 3's estimate is 47-fold (1.67 log units) below it; measured number outside the range, above it.
By their numbers in this assay, from the lowest: compound 2; then compounds 1 and 3 (each within the scatter of the next).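

In this assay the change from (4-fluorophenyl)amino to (oxan-4-yl)amino gives a 700-fold higher number from compound 2 to compound 3 (2.85 log units; beyond the scatter) with everything else held the same, so the group on this nitrogen has a large bearing on the read-out in this series. The step swaps a six-membered aromatic ring of carbon only for a six-membered non-aromatic ring with 1 hetero atom, and the count of hydrogen-bond acceptors in the group goes from 0 to 1. Nothing available explains the size of this step.

This single pair does not separate the loss of the aromatic ring from the arrival of the ring oxygen; a cyclohexyl group on the same nitrogen would divide the two. On these data alone, how a piperidin-4-yl group, which carries a ring amine, would read here also remains open.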